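The compounds below may be only part of what the source reports. "The series", "measured", "known", "first", "only" and "open" are said of these compounds alone.

Compound 3 `C=C1C[C@]23C[C@@]1(O)CC[C@H]2c1ccc(O)c(C)c1[C@@H]3Cn1cc(-c2ccccn2)nn1` has been run in a functional assay on A549 cells (Homo sapiens) for cytotoxicity, read by MTT assay, with a stated time of 4 days (a lower number here means a stronger inhibitor, a higher number a weaker inhibitor), where compound 3 gives only a limit of the assay, > 20000 nM. Compound 2 `C=C1C[C@]23C[C@@]1(O)CC[C@H]2c1cc(Br)c(O)c(C)c1[C@@H]3Cn1cc(-c2ccccn2)nn1`, which carries bromo on an aromatic carbon, likewise returns only a limit, > 20000 nM. Compound 1 `COc1ccc(-c2cn(C[C@H]3c4c(ccc(O)c4C)[C@@H]4CC[C@@]5(C)C[C@]43CC5=O)nn2)cc1`, built on a different core, also returns a limit, > 20000 nM. For the measured compounds named here, the one step between measured neighbours, a step that the two limits leave unreadable from compound 2 to compound 3, is therefore not readable, and the limit of > 20000 nM in this assay, at which 3 of the 3 values shown sit, is all the series shows so far. Compound 4 `C=C1C[C@]23C[C@@]1(O)CC[C@H]2c1ccc(O)c(C)c1[C@@H]3Cn1cc(-c2ccc(F)cc2)nn1` differs from compound 3 by 4-fluorophenyl in place of pyridin-2-yl on an aromatic carbon. Going by the values given here, no measured step touches this exchange on the five-membered aromatic ring with 3 nitrogen, and every value in hand sits at the limit, so there is no basis for expecting a reading inside the assay range. The step that the limit leaves unreadable from compound 3 to compound 4 is expected to stay within the scatter, most likely as a further limit. Compound 4 is estimated at 25000 nM, with a range from 8000 nM to 60000 nM.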

Compound 4, half-maximal inhibitory concentration: > 20000 nM
Compound 4 ended at the assay's limit (the forecaster's own chance of this, stated with the estimate: 80%); the middle value does not contradict the limit.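

Compound 3 and compound 4 both sit at a limit, so the exchange of 4-fluorophenyl in place of pyridin-2-yl yields no readable step. The compounds shown leave open whether any structure in this series reads inside the range of this assay, as everything so far stands at one value: the limit of > 20000 nM in this assay, at which 4 of the 4 values shown sit.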